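Swapping the Distal Aryl Group in a Biaryl Amide Series

The source may hold more compounds than are shown below. What is called first, only, known or untested is meant among the compounds shown, and "the series" means these compounds.

Compound 1 `CC(C)N(Cc1cccc(OCCCCCC(=O)O)c1)C(=O)c1ccc(-c2ccncc2)cc1`: in an ADME assay on HepG2 cells (Homo sapiens) for cytotoxicity, read by CellTiter-Glo and resazurin assay, with a stated time of 72 h (on this read-out higher numbers stand for an effect only at larger amounts of compound and lower numbers for an effect already at smaller amounts), compound 1 gives > 26000 nM, which is a limit of the assay.
Compound 2 `CC(C)N(Cc1cccc(OCCCCCC(=O)O)c1)C(=O)c1ccc(-c2ccco2)cc1`: in this assay compound 2 gives > 26000 nM, also a limit.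
Compound 3 `CC(C)N(Cc1cccc(OCCCCCC(=O)O)c1)C(=O)c1ccc(-c2ccc3[nH]ccc3c2)cc1`: in this assay compound 3 gives > 26000 nM, again a limit.

Compound 3 therefore stands only at a limit, and the two other values are limits as well, all three sitting at the limit of > 26000 nM in this assay, at which 3 of the 3 values shown sit. The measured steps a step that the two limits leave unreadable from compound 1 to compound 2, a step that the two limits leave unreadable from compound 1 to compound 3 and a step that the two limits leave unreadable from compound 2 to compound 3 give no readable size because every value rests at the limit of > 26000 nM in this assay, at which 3 of the 3 values shown sit. Compound 4 `CCOc1cccc(-c2ccc(C(=O)N(Cc3cccc(OCCCCCC(=O)O)c3)C(C)C)cc2)c1` differs from compound 3 by 3-ethoxyphenyl in place of 1H-indol-5-yl on an aromatic carbon. With no readable step to draw on, compound 4 is expected to show a step that the limit leaves unreadable from compound 3 to compound 4, without a direction that can be read. Compound 4 is estimated at 40000 nM in this assay, from 15000 nM to 120000 nM, most probably reported once more as a limit.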

Compound 4, half-maximal effective concentration: > 20800 nM
Compound 4 was reported as a limit; the forecaster's own chance of this, stated with the estimate: 80%; the middle value is on the limit's open side.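

Compound 4 is reported only as a limit in this assay, as are compound 1, compound 2 and compound 3, so none of its steps to them can be read. The compounds shown leave open whether these four distal groups differ at all in this assay.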